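A few compounds are considered here, and "the series" means these few. Any claim that something is new, unique, unknown or untested is made for them only; others in the source may bear on it.

Measured compounds in a functional assay on MCF7 cells (Homo sapiens) for cytotoxicity, read by MTT assay and propidium iodide staining, with a stated time of 24 h; on this read-out lower numbers stand for stronger inhibition and higher numbers for weaker inhibition:

Compound 1 `COc1ccc(-c2nnc(SCC(=O)c3ccccc3)o2)c(O)c1`: 280 nM
Compound 2 `Cc1ccc(-c2nnc(SCC(=O)c3ccc(Br)cc3)o2)c(O)c1`: 2070 nM
Compound 3 `O=C(CSc1nnc(-c2ccncc2)o1)c1ccc(Br)cc1`: 4230 nM

Compound 2 holds the second highest of the three numbers. Its value lies beyond the scatter from both of the others, with compound 1 clearly lower and compound 3 higher. The next compound, compound 4 `COc1ccc(-c2nnc(SCC(=O)c3ccc(Br)cc3)o2)c(O)c1`, has not yet been measured. It follows from compound 2 by one change, methoxy in place of methyl on an aromatic carbon.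

Among the measured compounds shown here, only one measured step links compounds that differ in one place. Pyridin-4-yl in place of 2-hydroxy-4-methylphenyl gives a 2.0-fold higher number from compound 2 to compound 3 (0.31 log units; beyond the scatter). That step is modest and replaces a whole group, so it is only a loose guide to a much smaller change. Bearing the methoxy but lacking the bromine that compound 2 carries, compound 1 reads 280 nM. It differs from compound 2 in two places, so its value cannot be assigned to the methoxy alone, though it does suggest the direction. In this assay a modest move to a lower number is therefore expected, and the expected step is a 2.1-fold lower number from compound 2 to compound 4 (0.32 log units; beyond the scatter). Compound 4 is estimated at 1000 nM, with an expected range of 300 nM to 3000 nM.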

Compound 4, half-maximal inhibitory concentration: 260 nM
Compound 4: middle estimate off by 3.8-fold (0.59 log units), on the high side; measured number below the stated range.
By their numbers in this assay, from the lowest: compounds 4 and 1 (each within the scatter of the next); then compound 2; then compound 3.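

In this assay the swap at this position carries a large step by itself: methoxy in place of methyl on an aromatic carbon, meta to a hydroxy group and para to a large group, gives an 8.0-fold lower number from compound 2 to compound 4 (0.90 log units; beyond the scatter) and so exceeds the whole-group replacement that gives a 2.0-fold higher number from compound 2 to compound 3 (0.31 log units; beyond the scatter). With the methoxy in place, bromo in place of hydrogen on an aromatic carbon gives a 1.1-fold lower number from compound 1 to compound 4 (0.03 log units; within the scatter) and so lies within the scatter, which means that compound 1 and compound 4 read alike in this pair and the bromine makes no measurable difference here. No experimental evidence on the origin of the methoxy step is available in the data shown.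

The compounds shown leave open whether the same position would tolerate an ethoxy group, an amine or a fluorine, and so whether the step belongs to methoxy specifically or to any group other than methyl. They also leave open whether bromo in place of hydrogen would stay as silent with the methyl of compound 2 at this position as it does with methoxy.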